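Demethylation of a Methoxyphenyl Pyrazole Urea Series

The source may report more compounds than this note shows. Statements on the series, on what has been measured and on what is new or still open speak of the compounds shown alone.

Compound 1, `COc1cc(-c2nn(-c3cccc(NC(=O)Nc4cc(C(F)(F)F)cc(C(F)(F)F)c4)c3)cc2-c2ccncc2)ccc1Cl`, gives 2190 nM in a functional assay on IGROV-1 cells (Homo sapiens) for inhibition, read by sulforhodamine B assay, with a stated time of 48 h; a higher number here means a weaker inhibitor of growth, a lower number a stronger inhibitor of growth.
Compound 2, `COc1cc(-c2nn(-c3cccc(NC(=O)Nc4ccc(Cl)c(Cl)c4)c3)cc2-c2ccncc2)ccc1Cl`, gives 3480 nM in this assay.
Compound 3, `O=C(Nc1cccc(-n2cc(-c3ccncc3)c(-c3ccc(Cl)c(O)c3)n2)c1)Nc1ccc(Cl)c(Cl)c1`, gives in this assay only a limit, > 32500 nM.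

Compound 1 and compound 2 carry the same core and differ in the aryl urea part; the difference between the two cores is not broken down here. Their two values lie within the scatter of each other, so no order can be read between them. Compound 3 is the partner of compound 2 with hydrogen in place of methyl on an oxygen on an aromatic ring. That change produced an at least 9.3-fold higher number from compound 2 to compound 3 (0.97 log units; beyond the scatter), and the value of compound 3 sits at the limit of > 32500 nM in this assay, at which 1 of the 3 values shown sits.

Compound 4, `O=C(Nc1cccc(-n2cc(-c3ccncc3)c(-c3ccc(Cl)c(O)c3)n2)c1)Nc1cc(C(F)(F)F)cc(C(F)(F)F)c1`, is not yet measured. It stands to compound 1 as compound 3 stands to compound 2, with the same change at the same place: hydrogen in place of methyl on an oxygen on an aromatic ring.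

Compound 4 is expected to give 30000 nM in this assay, with a likely range from 12000 nM to 80000 nM. The expectation means a 14-fold higher number from compound 1 to compound 4 (1.14 log units; beyond the scatter). It rests on the step of an at least 9.3-fold higher number from compound 2 to compound 3 (0.97 log units; beyond the scatter) applied to compound 1 from its value 2190 nM. Given that, compound 4 may well turn out beyond the reach of this assay.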

Compound 4, concentration for total growth inhibition: 3550 nM
Beside the measured number, compound 4's estimate is 8.5-fold (0.93 log units) above it; measured number below the stated range.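

In this assay, the change from methoxy to hydroxy gave a 1.6-fold higher number from compound 1 to compound 4 (0.21 log units; within the scatter), whereas the same change gave a clearly different result on the other core: the same change on two cores in this assay, an at least 9.3-fold higher number (0.97 log units; beyond the scatter) from compound 2 to compound 3 and a 1.6-fold higher number (0.21 log units; within the scatter) from compound 1 to compound 4, at least 5.7-fold (0.76 log units) apart, beyond the scatter of two such steps.
The value of compound 3, > 32500 nM, is a limit and not a number.
The two pairs show that the size of this step did not carry over from one core to the other in this series, but they do not show what sets the difference, and two pairs give no rule for predicting the step on a further core.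

The compounds shown hold only methoxy and hydroxy at this place, which leaves open what an ethoxy group or a carboxylic acid would give there. They also leave open how the change would read with an aryl urea part carrying a nitrile or a single trifluoromethyl group.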